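The compounds below may be only part of what the source reports. "The series", "measured", "known", "first", "only" and "open" are said of these compounds alone.

Three compounds have been measured in a functional assay on SK-MEL-2 cells (Homo sapiens) for cytotoxicity, read by MTT assay, with a stated time of 48 h; a higher number here means a weaker inhibitor, a lower number a stronger inhibitor:
Compound 1 `COCOCc1cc(OC)ccc1-c1cc2ccccc2c(=O)[nH]1` gives 97600 nM in this assay.
Compound 2 `C=CCn1c(-c2cc(OC)c(OC)cc2C=C)cc2ccccc2c1=O` gives 47700 nM in this assay.
Compound 3 `C=CCn1c(-c2ccc(OC)cc2C=C)cc2ccccc2c1=O` gives 11600 nM in this assay.

Compound 1 has the highest of the three numbers; compound 2 is nearest to it and compound 3 furthest. One change between measured compounds is seen once: from compound 3 to compound 2 the change is methoxy in place of hydrogen on an aromatic carbon, and it produced a 4.1-fold higher number from compound 3 to compound 2 (0.61 log units; beyond the scatter).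

Compound 4 `COCOCc1cc(OC)c(OC)cc1-c1cc2ccccc2c(=O)[nH]1` has not yet been measured. It differs from compound 1 by methoxy in place of hydrogen on an aromatic carbon. Among the compounds with values here, this is the same kind of change as the one from compound 3 to compound 2, but not the same: in compound 2 the entering methoxy is para to a vinyl group, whereas in compound 4 it is para to a (methoxymethoxy)methyl group. The difference between the core of compound 1 and the core of compound 3 is not broken down here.

Resting only on that single earlier step, the expectation is a rise of a 2.6-fold higher number from compound 1 to compound 4 (0.41 log units; beyond the scatter) in this assay. Compound 4 is therefore estimated at 250000 nM, most likely between 100000 nM and 600000 nM.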

Compound 4, half-maximal inhibitory concentration: 55200 nM
For compound 4 the middle estimate is 4.5-fold (0.66 log units) above the measured one; the measured number lies below the stated range.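

In this assay, methoxy in place of hydrogen gave a 1.8-fold lower number from compound 1 to compound 4 (0.25 log units; within the scatter), so on the core of compound 1 the change left no difference that can be told from repeat measurements, whereas on the other core it gave a 4.1-fold higher number from compound 3 to compound 2 (0.61 log units; beyond the scatter). Within the data shown here, the effect of this change therefore did not carry from one core to the other, and the two steps differ by more than their scatter: the same change on two cores in this assay, a 4.1-fold higher number (0.61 log units; beyond the scatter) from compound 3 to compound 2 and a 1.8-fold lower number (0.25 log units; within the scatter) from compound 1 to compound 4, 7.3-fold (0.86 log units) apart, beyond the scatter of two such steps This rests on only one pair per core, and the entering methoxy is para to a vinyl group in compound 2 but para to a (methoxymethoxy)methyl group in compound 4, so it does not show which of the differences between the two cores sets the size of the step.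

The compounds shown leave open how the step would behave with a hydroxymethyl group in place of the (methoxymethoxy)methyl group. They also leave open whether an amine or a carboxylic acid entering at the same aromatic carbon would give a different result from methoxy on either core.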